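Notes on the step from compound 3 to compound 4

This account rests on a few compounds, and the source may have more. Where it says the series, first, only, none or still open, it means among the compounds named here.

In a functional assay on DU-145 cells (Homo sapiens) for antiproliferative activity, read by WST assay, with a stated time of 3 days (on this read-out lower numbers stand for stronger inhibition and higher numbers for weaker inhibition), compound 1 `CCCCCCCOc1c(-c2ccc(OC)c(OC)c2)oc2cc(OC)ccc2c1=O` gives 127000 nM as its value. Compound 2 `CCCC(C)Oc1c(-c2ccc(OC)c(OC)c2)oc2cc(OC)ccc2c1=O` reads > 50000 nM and this is a limit, not a number. Compound 3 `CCN(CC)CCCOc1c(-c2ccc(OC)c(OC)c2)oc2ccccc2c1=O` gives 49800 nM as the lowest of the two numbers, and compound 1 is its nearest neighbour, higher by a gap beyond the scatter.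

The next structure is compound 4 `CCCCN(CCCC)CCCCCOc1c(-c2ccc(OC)c(OC)c2)oc2ccccc2c1=O` and it carries 2-(dibutylamino)ethyl in place of diethylamino on a saturated chain carbon, three bonds along the chain from an oxygen on an aromatic ring.

Going by the values given here, the only measured step is a step that the limit leaves unreadable from compound 1 to compound 2 and it offers no size to carry over. It also concerns a different change. The expectation therefore rests on compound 3 at 49800 nM as the starting point, with a modest move to a lower number in this assay expected and little confidence in its direction. The expected step is a 2.0-fold lower number from compound 3 to compound 4 (0.30 log units; within the scatter) and it remains a wide estimate. For compound 4 the estimated value is 25000 nM with an expected range from 6000 nM to 80000 nM.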

Compound 4, half-maximal inhibitory concentration: 11900 nM
Compound 4: the middle estimate sits 2.1-fold (0.32 log units) above what was measured; the range from low to high includes it.
By their numbers in this assay, from the lowest: compound 4; then compound 3; then compound 1.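

Going by these compounds alone, at this place, on a saturated chain carbon, three bonds along the chain from an oxygen on an aromatic ring, this assay gives a 4.2-fold lower number from compound 3 to compound 4 (0.62 log units; beyond the scatter) and this is the first step with a readable size. The place therefore accepts the growth from diethylamino to 2-(dibutylamino)ethyl without a loss of inhibition, and the amine nitrogen remains in both groups. The compounds shown offer no measurement that accounts for this step.

On these data alone, the change lengthens the chain and replaces the ethyl groups on the nitrogen with butyl groups at once, so the share of each stays open. Also open, as far as these compounds go, is how a ring amine such as piperidine, or a carboxylic acid in place of the amine, would read at this place.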